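Nitro in Place of Methoxy: An Estimate for Compound 3

A few compounds are considered here, and "the series" means these few. Any claim that something is new, unique, unknown or untested is made for them only; others in the source may bear on it.

Measured so far:
Compound 1, `COc1ccc(/C=N/NC(=O)c2ccc(C)cc2O)cc1`: in a functional assay (Mus musculus, strain BALB/C) for inhibition, read by MTT assay, with stated times of 24 h and 72 h (on this read-out higher numbers stand for weaker inhibition and lower numbers for stronger inhibition), compound 1 reaches only the limit > 100000 nM.
Compound 2, `Cc1ccc(C(=O)N/N=C/c2cc(Br)cc(Br)c2O)c(O)c1`: in this assay compound 2 gives 2020 nM.

Compound 1 stands at the limit of the assay rather than at a number (the limit of > 100000 nM in this assay, at which 1 of the 2 values shown sits). Of the two values shown, only compound 2 carries a measured figure, so compound 1 has no number of its own to build on. The unmeasured compound 3, `Cc1ccc(C(=O)N/N=C/c2ccc([N+](=O)[O-])cc2)c(O)c1`, differs from compound 1 by nitro in place of methoxy on an aromatic carbon. Within the data shown here, no step between measured compounds links these two, so the size of the step has to be guessed. In this assay a modest step toward stronger inhibition is expected, not far beyond the scatter, with compound 1 offering only a limit as the starting point. Compound 3 is therefore estimated at 60000 nM, between 15000 nM and 150000 nM, which means an expected step of an at least 1.6-fold lower number from compound 1 to compound 3 (0.22 log units; that floor lies within the scatter).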

Compound 3, half-maximal inhibitory concentration: 24300 nM
Compound 3: middle estimate off by 2.5-fold (0.39 log units), on the high side; low and high end bracket the measured number.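

Among these compounds, at this position, on an aromatic carbon para to a large group, nitro in place of methoxy brings the read-out in this assay from a limit to a measured number, which the earlier compounds could not show for this change. The change amounts to an at least 4.1-fold lower number from compound 1 to compound 3 (0.61 log units; beyond the scatter) and so shows that this position responds to the group placed on it. That size is only a floor and not the full step, because one end of the step is a limit: the limit of > 100000 nM in this assay, at which 1 of the 3 values shown sits.

Among the compounds shown, this position carries only methoxy and nitro, so a single change cannot show whether the step belongs to nitro in particular. As far as these compounds go, how an amine, a nitrile or a carboxylic acid at the same place would read in this assay remains open.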